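Cytotoxicity Limits for an Amide Pair and a Fluorinated Analogue

The source may hold more compounds than are shown below. What is called first, only, known or untested is meant among the compounds shown, and "the series" means these compounds.

In an ADME assay on HepG2 cells (Homo sapiens) for cytotoxicity, read by CellTiter-Glo and resazurin assay, with a stated time of 72 h (a lower number here means that less compound is needed, a higher number that more compound is needed for the effect), compound 2 `CCOC(=O)CCCCCOc1cccc(CN(C(=O)c2ccc(-c3cccnc3)cc2)C(C)C)c1` gives > 26000 nM, which is a limit of the assay rather than a measured number. Compound 1 `CC(C)N(Cc1cccc(OCCCCCC(=O)O)c1)C(=O)c1ccc(-c2cc3ccccc3n2S(=O)(=O)c2ccccc2)cc1` was tested in the same way and gives > 26000 nM, again a limit. The picture so far is therefore (the limit of > 26000 nM in this assay, at which 2 of the 2 values shown sit). The step to compound 3 `CCOC(=O)CCCCCOc1cccc(CN(C(=O)c2ccc(-c3cc(OC)ccc3F)cc2)C(C)C)c1` brings (2-fluoro-5-methoxyphenyl in place of pyridin-3-yl on an aromatic carbon). For the measured compounds named here, no measured step between compounds is available, so any expectation for compound 3 rests on the two limits and on the structural change alone. For compound 3 the expected step is a step that the limit leaves unreadable from compound 2 to compound 3, meaning no change beyond the usual scatter and a result that most likely sits once more at the limit of this assay. The estimate for compound 3 is 30000 nM, with a range from 12000 nM to 100000 nM.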

Compound 3, half-maximal effective concentration: > 26000 nM
Compound 3: only a limit was reported (the forecaster's own chance of this, stated with the estimate: 75%); the middle value lies beyond the limit too.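

Compound 2 and compound 3 both give only a limit in this assay, so no step can be read between them: the limit of > 26000 nM in this assay, at which 3 of the 3 values shown sit.

The compounds shown leave open at what concentration any of them would reach the half-maximal effect, and whether 2-fluoro-5-methoxyphenyl in place of pyridin-3-yl changes it.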